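A Methoxy Addition and Its Expected Effect on Cytotoxicity

The compounds below may be only part of what the source reports. "The series", "measured", "known", "first", "only" and "open" are said of these compounds alone.

Measured compounds:
compound 1 `COc1cc(CNC(=O)/C=C/c2ccccc2)ccc1OCc1nc(C)c(C)nc1C`: 7310 nM
compound 2 `COc1ccc(/C=C/C(=O)NCc2ccc(OCc3nc(C)c(C)nc3C)c(OC)c2)cc1`: 5050 nM
compound 3 `COc1cc(CNC(=O)/C=C/c2cccc(OC)c2OC)ccc1O`: 5490 nM

These three compounds were tested in a functional assay on SH-SY5Y cells (Homo sapiens) for cytotoxicity, read by MTT assay, with stated times of 24 h and 4 h; on this read-out lower numbers stand for an effect already at smaller amounts and higher numbers for an effect only at larger amounts of compound. Compound 1 gives 7310 nM, compound 2 gives 5050 nM and compound 3 gives 5490 nM; all three numbers lie within the scatter of one another, so none of them can be set apart as more or less active.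

Compound 1 and compound 2 differ in one place, (methoxy in place of hydrogen on an aromatic carbon), and this change made a 1.4-fold lower number from compound 1 to compound 2 (0.16 log units; within the scatter). Compound 3 carries a different core from compound 1; how the two cores differ is not broken down here.

Compound 4 `COc1cc(CNC(=O)/C=C/c2ccc(OC)c(OC)c2OC)ccc1O` is not yet measured. It differs from compound 3 by methoxy in place of hydrogen on an aromatic carbon. Among the compounds with values here, this is the same kind of change as the one from compound 1 to compound 2, but the surroundings of the place are not identical: in compound 3 the entering group also sits ortho to a methoxy group and meta to a methoxy group, whereas in compound 1 the place is only para to a large group.

Since the earlier step, a 1.4-fold lower number from compound 1 to compound 2 (0.16 log units; within the scatter), stayed within the scatter, compound 4 is expected to show a step of a 1.2-fold lower number from compound 3 to compound 4 (0.09 log units; within the scatter) in this assay. Compound 4 is therefore estimated at 4500 nM, with a likely range from 2200 nM to 9500 nM.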

Compound 4, half-maximal effective concentration: 7450 nM
The estimate for compound 4 lay 1.7-fold (0.22 log units) below the measured number; measured number inside the range.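

In this assay, the methoxy group entering on the aromatic carbon of compound 3 gave a 1.4-fold higher number from compound 3 to compound 4 (0.13 log units; within the scatter), so on this core the change produced no difference that can be read apart from repeat-measurement noise. Set beside the earlier step, the two results give no sign that the core matters for this change: the same change on two cores in this assay, a 1.4-fold lower number (0.16 log units; within the scatter) from compound 1 to compound 2 and a 1.4-fold higher number (0.13 log units; within the scatter) from compound 3 to compound 4, 2.0-fold (0.29 log units) apart, within the scatter of two such steps. This shows only that the methoxy addition stayed within the scatter on both cores; it does not show that the change carries a consistent effect from one core to the other, and with just two pairs, neither step distinguishable from no change, it cannot show that the cores respond alike or differently to a change that has a real effect.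

The compounds shown leave open whether any group at this place moves the number in this assay beyond the scatter, for example an amine, a carboxylic acid or a longer chain such as ethoxy in place of methoxy. They also leave open whether such a group would give the same step on the core of compound 1 and on the core of compound 3.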